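The source may hold more compounds than are shown below. What is called first, only, known or untested is meant among the compounds shown, and "the series" means these compounds.

In an ADME assay on microsomes from liver (Mus musculus) for metabolic stability, with a stated time of 30 min, tested at 1 uM (a lower number here means that less of the compound is left, a higher number that more of the compound is left), three compounds of the series have readings. Compound 1 (`CC[C@@H]1C(=O)N(C)c2cnc(-c3cn[nH]c3-c3ccc(F)cc3F)nc2N1c1cnn(C)c1`) stands lowest (5%), compound 3 (`CCC1C(=O)N(C)c2cnc(-n3ccnc3-c3ccc(F)cc3)nc2N1c1ccc(F)cc1`) highest (41%) and compound 2 (`CC[C@@H]1C(=O)N(C)c2cnc(-n3ccnc3-c3ccccc3)nc2N1[C@@H]1CCOC1`) second (27%), with both gaps from compound 2 beyond the scatter. The step to compound 4 (`CC[C@@H]1C(=O)N(C)c2cnc(-n3ccnc3-c3ccccc3)nc2N1CCC(F)(F)F`) puts 3,3,3-trifluoropropyl in place of oxolan-3-yl on a nitrogen on an aromatic ring in a ring. Going by the values given here, no measured pair isolates this change, so the only anchor is compound 2 at 27% and confidence is limited. A small upward step is expected, estimated as a number 6 percentage points higher from compound 2 to compound 4 (within the scatter) and probably not beyond the scatter. For compound 4 the estimated value is 33% with an expected range from 14% to 55% in this assay as the next reading.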

Compound 4, percent of the compound remaining: 2%
Compound 4: the middle estimate sits 31 percentage points above what was measured, outside the stated range (below it).
By their numbers in this assay, from the lowest: compounds 4 and 1 (each within the scatter of the next); then compound 2; then compound 3.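

Going by these compounds alone, this is the only pair that differs in one place, and it shows that the group on this nitrogen can alone move the reading in this assay: replacing oxolan-3-yl with 3,3,3-trifluoropropyl gives a number 25 percentage points lower from compound 2 to compound 4 (beyond the scatter) and a result beyond the scatter. Nothing available accounts for this step.

The compounds shown leave open whether the step goes with losing the ring or with gaining the fluorines. A plain propyl chain on the same nitrogen would separate the two.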